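Aryl amide series: fluoro to methyl swap

The source may hold more compounds than are shown below. What is called first, only, known or untested is meant among the compounds shown, and "the series" means these compounds.

Measured so far in an in vitro ADME assay on microsomes from liver (Mus musculus) for pharmacokinetics, read by LC-MS, with a stated time of 10 min, tested at 1 uM (on this read-out lower numbers stand for slow clearance and higher numbers for fast clearance), as clearance:
compound 1 `CN1C[C@H](C(=O)Nc2ccccc2)[C@@H](c2ccc(/C=C/C(=O)Nc3ccccc3N)cc2)C1` gives 67 mL/min/kg here
compound 2 `CN1C[C@H](C(=O)Nc2ccc(F)cc2)[C@@H](c2ccc(/C=C/C(=O)Nc3ccccc3N)cc2)C1` gives 34 mL/min/kg here

Going by the values given here, compound 2 stands within the scatter of compound 1, the only other measured compound. The next change, to compound 3 `Cc1ccc(NC(=O)[C@H]2CN(C)C[C@@H]2c2ccc(/C=C/C(=O)Nc3ccccc3N)cc2)cc1`, is methyl in place of fluoro on an aromatic carbon and amounts to methyl in place of fluoro on an aromatic carbon. Among the compounds with values here, the one step bearing on it is a 2.0-fold lower number from compound 1 to compound 2 (0.29 log units; within the scatter) for fluoro in place of hydrogen on an aromatic carbon. Within the data shown here, no measured compound carries the methyl, so no step beyond the scatter is expected in this assay here. The expected step is a 1.4-fold higher number from compound 2 to compound 3 (0.15 log units; within the scatter) on this estimate. Compound 3 is estimated at 48 mL/min/kg with an expected range from 24 mL/min/kg to 95 mL/min/kg for now.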

Compound 3, clearance: 62 mL/min/kg
Beside the measured number, compound 3's estimate is 1.3-fold (0.11 log units) below it; the range from low to high includes it.
By their numbers in this assay, from the lowest: compounds 2, 3 and 1 (each within the scatter of the next).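

In this assay methyl in place of fluoro on this aromatic carbon, para to a large group, gives a 1.8-fold higher number from compound 2 to compound 3 (0.26 log units; within the scatter) and methyl in place of hydrogen gives a 1.1-fold lower number from compound 1 to compound 3 (0.03 log units; within the scatter) at the same place. Hydrogen, fluoro and methyl here therefore stand within the scatter of one another, so no group at this place has yet separated from the others on clearance. No evidence on the cause of these numbers is available.

Going by these compounds, whether methoxy, trifluoromethyl or an amine at this place would give a step beyond the scatter remains open.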